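The source may hold more compounds than are shown below. What is called first, only, known or untested is meant among the compounds shown, and "the series" means these compounds.

Measured compounds:
Compound 1 `CN(C)CCn1cnnc1-c1cc(Oc2ccc(NC(=O)N/N=C/c3ccc(Cl)cc3Cl)cc2F)ccn1` gives 130 nM in a functional assay on NCI-H460 cells (Homo sapiens) for cytotoxicity, read by MTT assay, with a stated time of 72 h; on this read-out lower numbers stand for stronger inhibition and higher numbers for weaker inhibition.
Compound 2 `COc1ccc(OC)c(/C=N/NC(=O)Nc2ccc(Oc3ccnc(-c4nncn4CCN(C)C)c3)c(F)c2)c1` gives 2930 nM.
Compound 3 `CN(C)CCn1cnnc1-c1cc(Oc2ccc(NC(=O)N/N=C/c3ccc(F)cc3F)cc2F)ccn1` gives 1930 nM.

Compound 2 has the highest number of the three. Its gap to compound 3 is only a 1.5-fold lower number from compound 2 to compound 3 (0.18 log units; within the scatter), within the scatter, while compound 1 lies far off: a 23-fold higher number from compound 1 to compound 2 (1.35 log units; beyond the scatter).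

Compound 4 `CN(C)CCn1cnnc1-c1cc(Oc2ccc(NC(=O)N/N=C/c3cccc(Cl)c3Cl)cc2F)ccn1` differs from compound 2 in one place: 2,3-dichlorophenyl in place of 2,5-dimethoxyphenyl on a carbon with a double bond to nitrogen. For the measured compounds named here, two measured steps bear on this. The step of a 23-fold higher number from compound 1 to compound 2 (1.35 log units; beyond the scatter) shows that the dichlorinated ring of compound 1 gives a much lower number than the dimethoxy ring, and a 15-fold higher number from compound 1 to compound 3 (1.17 log units; beyond the scatter) shows that swapping its chlorines for fluorines also raises the number. Going by the values given here, compound 4 keeps two chlorines, though at different places, and no measured pair shows whether that placement matters. A large downward step is therefore expected, a 7.3-fold lower number from compound 2 to compound 4 (0.86 log units; beyond the scatter), though possibly short of compound 1. Compound 4 is estimated at 400 nM, with a range from 100 nM to 1600 nM.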

Compound 4, half-maximal inhibitory concentration: 72 nM
For compound 4 the middle estimate is 5.6-fold (0.74 log units) above the measured one; measured number outside the range, below it.
By their numbers in this assay, from the lowest: compounds 4 and 1 (each within the scatter of the next); then compounds 3 and 2 (each within the scatter of the next).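

In this assay, the two chlorine placements cannot be told apart (a 1.8-fold lower number from compound 1 to compound 4 (0.26 log units; within the scatter)). The 2,3-dichlorophenyl ring also stands far from the other two rings (a 41-fold lower number from compound 2 to compound 4 (1.61 log units; beyond the scatter); a 27-fold lower number from compound 3 to compound 4 (1.43 log units; beyond the scatter)), so at this position two chlorines gave low numbers in both placements shown, while the 2,5-dimethoxyphenyl and 2,4-difluorophenyl rings did not. Nothing available explains this gap between the rings.

Still open, from the compounds shown here alone, is whether both chlorines are needed, or whether a ring with one chlorine would do as well. Going by these compounds, whether two bromine atoms or two methyl groups could take their place also remains unknown.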